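Diethylamino for dimethylamino on the side chain

The source may hold more compounds than are shown below. What is called first, only, known or untested is meant among the compounds shown, and "the series" means these compounds.

Compound 1, `CN(C)CCNc1nc(-c2ccc(NC(=O)Nc3ccc(F)cc3)cc2)nc2c(Cl)c(Cl)sc12`, gives 1350 nM in a functional assay on MKN-45 cells (Homo sapiens) for cytotoxicity, read by MTT assay, with a stated time of 72 h; on this read-out higher numbers stand for weaker inhibition and lower numbers for stronger inhibition.
Compound 2, `CN(C)CCNc1nc(-c2ccc(NC(=O)Nc3ccc(Cl)cc3)cc2)nc2c(Cl)c(Cl)sc12`, gives 910 nM in this assay.

Among the compounds with values here, compound 1 stands at the upper of the two numbers, yet the only step, a 1.5-fold lower number from compound 1 to compound 2 (0.17 log units; within the scatter), is within the scatter. Compound 3, `CCN(CC)CCNc1nc(-c2ccc(NC(=O)Nc3ccc(F)cc3)cc2)nc2c(Cl)c(Cl)sc12`, differs from compound 1 by diethylamino in place of dimethylamino on a saturated chain carbon, two bonds along the chain from a nitrogen on an aromatic ring. Within the data shown here, no measured step touches this group; the one step measured concerns chloro in place of fluoro on an aromatic carbon and was within the scatter. With nothing bearing on the change, no step beyond the scatter is expected in this assay, no change at the digits printed from compound 1 to compound 3 (within the scatter). Compound 3 is thus estimated at 1350 nM, within 450 nM to 4000 nM.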

Compound 3, half-maximal inhibitory concentration: 1370 nM
The estimate for compound 3 lay 1.0-fold (0.01 log units) below the measured number; low and high end bracket the measured number.
By their numbers in this assay, from the lowest: compounds 2, 1 and 3 (each within the scatter of the next).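

In this assay, the side chain now has a measured step of its own: diethylamino in place of dimethylamino gives a 1.0-fold higher number from compound 1 to compound 3 (0.01 log units; within the scatter). On the fluoro compounds, this position therefore takes either amine with no difference beyond the scatter. No measurement shown explains this result.

Still open, from the compounds shown here alone, is whether a ring amine such as morpholine or piperidine, or a longer chain between the two nitrogens, would keep the number in this range. Going by these compounds, the same exchange on the chloro compound, compound 2, also remains open.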